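Dropping a Hydroxy Group from a Cytotoxicity-Inactive Compound

This account rests on a few compounds, and the source may have more. Where it says the series, first, only, none or still open, it means among the compounds named here.

Compound 1 `CC(C)=CCOc1ccc(C(=O)/C=C/c2ccc(O)cc2)c(O)c1`: > 100000 nM
Compound 2 `COc1cc(/C=C/CO)cc(OC)c1O`: > 100000 nM

In a functional assay on SK-MEL-28 cells (Homo sapiens) for cytotoxicity, read by MTT assay, with a stated time of 72 h (on this read-out higher numbers stand for weaker inhibition and lower numbers for stronger inhibition), compound 1 gives > 100000 nM, which is a limit of the assay rather than a measured number. Compound 2 likewise gives > 100000 nM, again a limit. Both values shown therefore rest at the same ceiling (the limit of > 100000 nM in this assay, at which 2 of the 2 values shown sit), so compound 1 stands nowhere distinct among the compounds measured; neither of them showed measurable cytotoxicity on these cells. Among the compounds with values here, no step between measured compounds is available.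

Compound 3 `CC(C)=CCOc1ccc(C(=O)/C=C/c2ccccc2)c(O)c1` has not yet been tested. It differs from compound 1 in one place: hydrogen in place of hydroxy on an aromatic carbon. Nothing measured here shows how such a change acts, and because both shown values sit at the limit of > 100000 nM in this assay, at which 2 of the 2 values shown sit, the expected step that the limit leaves unreadable from compound 1 to compound 3 in this assay is none beyond the scatter. Compound 3 is accordingly estimated to give 150000 nM, with a range from 40000 nM to 500000 nM, most probably reported once more only as a limit.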

Compound 3, half-maximal inhibitory concentration: 81000 nM
Compound 3: the middle estimate sits 1.9-fold (0.27 log units) above what was measured, and the stated range covers the measured number.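

In this assay, the change from 4-hydroxyphenyl to phenyl gives an at least 1.2-fold lower number from compound 1 to compound 3 (0.09 log units; that floor lies within the scatter). That figure is only a floor, because compound 1 has no number of its own, just a limit: the limit of > 100000 nM in this assay, at which 2 of the 3 values shown sit. Within the data shown here, compound 3 is the first compound here to return a measured number rather than a limit, so the phenyl form can be read in this assay, but the floor alone does not establish a real gain from losing the hydroxy group.

Going by these compounds, it remains open how other groups at this place, such as a methoxy group, a fluorine atom or an amine, would act on the core of compound 1. Also open, on these data alone, is whether the same swap of hydroxy for hydrogen would have a clearly readable effect on a core that starts from a measured number.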